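Acetyl to pyridin-3-yl carbonyl on a shared core

The source may report more compounds than this note shows. Statements on the series, on what has been measured and on what is new or still open speak of the compounds shown alone.

Of the compounds shown here, two have been measured so far. Compound 1 `CC(=O)Nc1nc(C)nc2cn(-c3ccccc3)nc12` in an assay on CHO cells for displacement of a labelled ligand from adenosine receptor A1 (Homo sapiens), read by scintillation counting, with a stated time of 120 min, tested at 1 uM (on this read-out lower numbers stand for less inhibition and higher numbers for more inhibition at the one concentration tested (going by the name of the read-out)), gives 25%, the highest of the two numbers. Going by the values given here, compound 2 `O=C(Nc1nc(-c2ccccc2)nc2cn(-c3ccccc3)nc12)c1ccccc1` in this assay gives 5%, a number lower than that of compound 1 by more than the scatter; the two compounds differ at more than one place, so no single step links them. Compound 3 `Cc1nc(NC(=O)c2cccnc2)c2nn(-c3ccccc3)cc2n1` has not yet been measured. It differs from compound 1 in one place: pyridin-3-yl in place of methyl on a carbonyl carbon. Among the compounds with values here, no measured pair isolates this change, so the expectation rests on the two values alone. Since compound 2 gives 5% in this assay, a modest fall is expected, one that may still lie within the scatter. The step from compound 1 to compound 3 is expected to be a number 7 percentage points lower from compound 1 to compound 3 (within the scatter). Compound 3 is therefore expected to give 18%, between 3% and 40%.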

Compound 3, a percentage reported as inhibition, at one concentration (the size of the read-out at that concentration, not a potency): 12%
For compound 3 the middle estimate is 6 percentage points above the measured one, and the stated range covers the measured number.
By their numbers in this assay, from the lowest: compounds 2 and 3 (each within the scatter of the next); then compound 1.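

In this assay, going by these compounds alone, the step from acetyl to (pyridin-3-yl)carbonyl is a number 13 percentage points lower from compound 1 to compound 3 (beyond the scatter), the first change in this set that can be read at a single place. It shows that the group on this carbonyl carbon, whose other neighbour is the amide-type nitrogen, affects the read-out on the shared core, and that pyridin-3-yl in place of methyl lowers the inhibition by a modest amount. No supporting data bear on why this step goes in this direction.

From the compounds shown here alone, what remains open is whether the ring as such or its nitrogen accounts for the step, which a plain phenyl on the same carbonyl carbon would help to separate. Going by these compounds, it is also open how a longer chain such as propyl, or an amine carried on this carbon, would read in this assay.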